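Two aryl pairs on related cores: bromo to methyl

The source may report more compounds than this note shows. Statements on the series, on what has been measured and on what is new or still open speak of the compounds shown alone.

Measured so far:
compound 1, `Cc1ccc(-c2c(S(=O)(=O)c3ccccc3)cnc3ncnn23)cc1`, 7.5%
compound 2, `O=S(=O)(c1ccccc1)c1cnc2ncnn2c1-c1ccc(Br)cc1`, 2.2%
compound 3, `Cc1ccc(-c2c(S(=O)(=O)c3ccccc3)cnc3cc(-c4ccc(Br)cc4)nn23)cc1`, 74.1%

Of the compounds shown here, three have been tested in a functional assay on the whole organism for inhibition, with Mus musculus as the target, with a stated time of 1 h, at a dose of 50 mg/kg by the oral route; on this read-out higher numbers stand for more inhibition at the one dose given (going by the name of the read-out) and lower numbers for less inhibition. Compound 2 gives 2.2% and compound 1 gives 7.5%; the change between them, (methyl in place of bromo on an aromatic carbon), produced a number 5.3 percentage points higher from compound 2 to compound 1 (within the scatter). Compound 3 gives 74.1%, the highest of the three, with its steps to compound 1 and compound 2 both beyond the scatter. The difference between the core of compound 3 and the core of compound 2 is not broken down here. Compound 4, `Cc1ccc(-c2cc3ncc(S(=O)(=O)c4ccccc4)c(-c4ccc(C)cc4)n3n2)cc1`, is not yet measured; it differs from compound 3 by methyl in place of bromo on an aromatic carbon, the same change as seen from compound 2 to compound 1. Because that earlier step was a number 5.3 percentage points higher from compound 2 to compound 1 (within the scatter), the step is expected to be small, with compound 4 estimated at a number 1.9 percentage points higher from compound 3 to compound 4 (within the scatter) from compound 3. In this assay compound 4 is therefore expected to give about 76%, within a range of 56% to 92%.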

Compound 4, a percentage reported as inhibition, in the whole organism at one dose (the size of the read-out at that dose, not a potency): 54.6%
Compound 4: middle estimate off by 21.4 percentage points, on the high side; measured number outside the range, below it.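

In this assay, the change of 4-bromophenyl to 4-methylphenyl gave a number 19.5 percentage points lower from compound 3 to compound 4 (beyond the scatter). For the compounds shown here, the step therefore does not carry over at the same size from one core to the other: the same change on two cores in this assay, a number 5.3 percentage points higher (within the scatter) from compound 2 to compound 1 and a number 19.5 percentage points lower (beyond the scatter) from compound 3 to compound 4, 24.8 percentage points apart, beyond the scatter of two such steps This rests on only two pairs, so it shows that the core can matter to this change, but it does not show why the steps differ or how the change would behave on any further core.

The compounds shown leave open how a methoxy group, an amine or a carboxylic acid would read in place of bromo or methyl on that ring. They also leave open whether any such group would give the same step on both cores.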